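The source may hold more compounds than are shown below. What is called first, only, known or untested is meant among the compounds shown, and "the series" means these compounds.

In a functional assay on A549 cells (Homo sapiens) for cytotoxicity, read by MTT assay, with a stated time of 48 h (a lower number here means a stronger inhibitor, a higher number a weaker inhibitor), compound 1 `CCn1c(/C=C2/C(=O)Nc3ccccc32)nc2ccccc21` gives > 50000 nM, which is a limit and not a number. Compound 2 `CCn1c(/C=C2/C(=O)Nc3ccc(C)cc32)nc2ccccc21` gives > 50000 nM, also a limit. Within the data shown here, compound 3 `Cn1c(/C=C2/C(=O)Nc3ccc(Cl)cc32)nc2ccccc21` gives 39700 nM, the only true number so far. Compound 4 `CCn1c(/C=C2/C(=O)Nc3ccc(Cl)cc32)nc2ccccc21` changes compound 3 by methyl in place of hydrogen on a saturated chain carbon bound to an aromatic nitrogen, which reads as methyl to ethyl. Among the measured compounds shown here, the one measured step, a step that the two limits leave unreadable from compound 1 to compound 2, lies at a different place and gives no size to carry over. Compound 1 and compound 2, both with ethyl, mark (the limit of > 50000 nM in this assay, at which 2 of the 3 values shown sit). Taking compound 3 at 39700 nM as the anchor, no change beyond the scatter is expected in this assay, and the estimated step is a 1.1-fold higher number from compound 3 to compound 4 (0.05 log units; within the scatter). The estimate for compound 4 is 45000 nM, expected within 22000 nM to 90000 nM.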

Compound 4, half-maximal inhibitory concentration: > 50000 nM
Compound 4 was reported as a limit (the forecaster's own chance of this, stated with the estimate: 45%); middle value at least 1.1-fold (0.04 log units) away from the limit.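

At the chain carbon bound to the aromatic nitrogen, methyl to ethyl gives an at least 1.2-fold higher number from compound 3 to compound 4 (0.10 log units; that floor lies within the scatter), so this first readable step in the series sets only a floor, not a size. Compound 4 is a limit, and with ethyl on the core, chloro on the aromatic carbon leaves the steps among compound 1, compound 2 and compound 4 unreadable. Compound 3 therefore remains the only true number in this assay, and the rest of the series sits at one ceiling: the limit of > 50000 nM in this assay, at which 3 of the 4 values shown sit.

From the compounds shown here alone, how far compound 4 actually lies from compound 3 stays open. Also open, going by these compounds, is whether a longer chain such as propyl, or methoxy in place of chloro, would bring a readable number.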